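Amide substituent changes on the shared boron-containing core

The source may hold more compounds than are shown below. What is called first, only, known or untested is meant among the compounds shown, and "the series" means these compounds.

The series shares the core seen in compound 1 `CC(C)(C)NC(=O)CCc1cccc2c1B(O)OC2`, which carries a tert-butyl on the amide-type nitrogen. In a functional assay on HCT-116 cells (Homo sapiens) for antiproliferative activity, read by MTT assay, with a stated time of 72 h (on this read-out lower numbers stand for stronger inhibition and higher numbers for weaker inhibition), compound 1 gives > 100000 nM, a limit of the assay and not a number. Compound 2 `O=C(CCc1cccc2c1B(O)OC2)Nc1ccc(I)cc1` has 4-iodophenyl in place of tert-butyl on an amide-type nitrogen. In this assay, within the data shown here, compound 2 gives 50000 nM, the only number so far. Among the measured compounds shown here, the one further value is the limit (the limit of > 100000 nM in this assay, at which 1 of the 2 values shown sits). The step of an at least 2.0-fold lower number from compound 1 to compound 2 (0.30 log units; that floor lies within the scatter) reaches only the floor set by that limit, and that floor lies within the scatter.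

Compound 3 `O=C(CCc1cccc2c1B(O)OC2)Nc1ccc([N+](=O)[O-])cc1` differs from compound 2 by nitro in place of iodo on an aromatic carbon. For the measured compounds named here, no measured step exchanges a group on an aromatic carbon of a six-membered aromatic ring of carbon only; the single recorded step replaces the whole group on the amide-type nitrogen, so it does not bear on this exchange. No step beyond the scatter is therefore expected. Compound 3 is estimated at 50000 nM, with a range from 15000 nM to 150000 nM. The expected step of no change at the digits printed from compound 2 to compound 3 (within the scatter) stays within the scatter.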

Compound 3, half-maximal inhibitory concentration: > 100000 nM
Compound 3 gave a limit, no number (the forecaster's own chance of this, stated with the estimate: 35%); middle value at least 2.0-fold (0.30 log units) from the limit.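

In this assay compound 3 gives > 100000 nM, which is a limit of the assay and not a number. Among these compounds, this is the first reading of an exchange on the aromatic carbon para to a large group: the step of an at least 2.0-fold higher number from compound 2 to compound 3 (0.30 log units; that floor lies within the scatter) reaches only the floor set by that limit, so its true size remains unknown, and nitro in place of iodo shows no gain on this read-out. Iodo is now the only group at this position with a number, and compound 2 is the only compound in the series to have one, which leaves the values shown crowded at one end of the read-out: the limit of > 100000 nM in this assay, at which 2 of the 3 values shown sit.

Still open, from the compounds shown here alone, is whether another group on this aromatic carbon, such as an amine, a carboxylic acid or a methoxy group, would give a number clearly apart from that of compound 2. Also open, going by these compounds, is whether a longer chain in place of the one linking the amide carbonyl to the shared core would bring the series clear of the limit.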